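This account rests on a few compounds, and the source may have more. Where it says the series, first, only, none or still open, it means among the compounds named here.

Measured in a functional assay on LNCaP C4-2B cells (Homo sapiens) for cytotoxicity, read by MTT assay, with a stated time of 72 h; a higher number here means a weaker inhibitor, a lower number a stronger inhibitor:
- compound 1 (`COc1cc(/C=C/C(=O)/C(=C/c2ccc3ccccc3n2)C(=O)/C=C/C2=C(C)CCCC2(C)C)ccc1O`) : 5300 nM
- compound 2 (`COc1cc(/C=C/C(O)=C/C(=O)/C=C/C2=C(C)CCCC2(C)C)ccc1O`) : 44300 nM

Compound 1 has the lower number of the two, well clear of compound 2 at 44300 nM. Compound 3 (`COc1cc(/C=C(\C(=O)/C=C/C2=C(C)CCCC2(C)C)C(=O)/C=C/c2ccc(O)c(OC)c2)ccc1O`) departs from compound 1 by one change: 4-hydroxy-3-methoxyphenyl in place of quinolin-2-yl on a double-bonded chain carbon bound to a double-bonded chain carbon. This is 4-hydroxy-3-methoxyphenyl in place of quinolin-2-yl on a double-bonded chain carbon bound to a double-bonded chain carbon. For the measured compounds named here, no measured pair tests this swap, so in this assay no step beyond the scatter is expected, with a slight lean towards a higher number. The estimated change is a 1.5-fold higher number from compound 1 to compound 3 (0.18 log units; within the scatter). Compound 3 is expected at 8000 nM, with an estimated range from 2500 nM to 25000 nM.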

Compound 3, half-maximal inhibitory concentration: 1600 nM
For compound 3 the middle estimate is 5.0-fold (0.70 log units) above the measured one, outside the stated range (below it).
By their numbers in this assay, from the lowest: compound 3; then compound 1; then compound 2.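

In this assay, 4-hydroxy-3-methoxyphenyl in place of quinolin-2-yl on a double-bonded chain carbon bound to a double-bonded chain carbon gives a 3.3-fold lower number from compound 1 to compound 3 (0.52 log units; beyond the scatter) on the shared core, so this position responds to the group it carries. The swap changes aromatic ring content and hydrogen-bond donors together, and this single step cannot assign the gain to either. Nothing available explains the step.

Open, on these data alone, is how a plain phenyl or a pyridin-2-yl group would compare at this position. Also open, as far as these compounds go, is whether the hydroxy or the methoxy of 4-hydroxy-3-methoxyphenyl matters more here.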